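The source may report more compounds than this note shows. Statements on the series, on what has been measured and on what is new or still open speak of the compounds shown alone.

Working notes on the series. Compound 1 `Fc1ccc(Oc2cncc(C3=CC4CNCC(C3)C4)c2)cc1` is measured in an in vitro assay on SH-EP1 cells for displacement of a labelled ligand from Neuronal acetylcholine receptor; alpha4/beta2 (Homo sapiens) (a lower number here means a stronger inhibitor, a higher number a weaker inhibitor), and gives 0.6 nM. Two further members are measured. Compound 2 `CC(C)Oc1cncc(C2=CC3CC(C2)CN(C)C3)c1` gives 2.2 nM in this assay. Compound 3 `COc1cc(C2=CC3CNCC(C2)C3)cnc1Cl` gives 0.4 nM in this assay. Of the three numbers compound 1 holds the second highest. Its gap to compound 3 lies within the usual scatter, so the two cannot be ordered. Compound 2 sits at a higher number, and that gap lies beyond the scatter.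

Compound 4 `C1=C(c2cncc(OCc3ccccc3)c2)CC2CNCC1C2` has not been measured. It differs from compound 1 in one place: benzyl in place of 4-fluorophenyl on an oxygen on an aromatic ring. Within the data shown here, no pair of measured compounds differs in a single place, so no step of this kind can be read from the series itself. What the data do show is that compound 2 and compound 3, which each carry a different group on an oxygen on an aromatic ring, both stay in the low range.

For compound 4 the expectation is a modest move toward a higher number, with the step from compound 1 to compound 4 estimated at a 2.5-fold higher number from compound 1 to compound 4 (0.40 log units; beyond the scatter), roughly at the edge of the scatter. The estimate for compound 4 in this assay is 1.5 nM, with a range from 0.5 nM to 5 nM.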

Compound 4, inhibition constant: 0.7 nM
The estimate for compound 4 lay 2.1-fold (0.33 log units) above the measured number, within the range that was stated.
By their numbers in this assay, from the lowest: compounds 3, 1 and 4 (each within the scatter of the next); then compound 2.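

Benzyl in place of 4-fluorophenyl on an oxygen on an aromatic ring gives a 1.2-fold higher number from compound 1 to compound 4 (0.07 log units; within the scatter) in this assay, the first change in the series that can be read in a single place. At this position, then, a fluorine-bearing aromatic group and a group of seven carbon atoms, each with one six-membered aromatic ring of carbon only, cannot be told apart in this measurement, although the exchange alters both the atoms present and the way the ring is attached to the oxygen. No independent measurement is at hand that explains this result.

Steps from compound 1 or compound 4 to compound 2 or compound 3 cannot be read, as those pairs differ in more than one place, and this single step does not separate the loss of the fluorine from the change in attachment, a question that phenyl or 4-fluorobenzyl on the same oxygen would address. Also open, from the compounds shown here alone, is whether the same position accepts a group of a different kind, such as a longer chain ending in phenyl, an amine or a carboxylic acid.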